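Alkoxy Anilide Versus Benzyl Amide: Estimating Compound 3

The compounds below may be only part of what the source reports. "The series", "measured", "known", "first", "only" and "open" are said of these compounds alone.

Of the compounds shown here, two built on one shared core have been tested in a functional assay on A549 cells (Homo sapiens) for inhibition, read by MTT assay, with a stated time of 48 h; a lower number here means a stronger inhibitor, a higher number a weaker inhibitor. Compound 1 `COc1cccc(NC(=O)/C=C/c2coc3cc(OC)ccc3c2=O)c1` gives 12800 nM. Compound 2 `COc1ccc(CNC(=O)/C=C/c2coc3cc(OC)ccc3c2=O)cc1` gives 22500 nM. Among the measured compounds shown here, the one measured step, a 1.8-fold higher number from compound 1 to compound 2 (0.24 log units; within the scatter), means these two numbers cannot be told apart, so compound 2 stands level with compound 1 rather than clearly apart from it.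

Compound 3 `CCOc1ccc(NC(=O)/C=C/c2coc3cc(OC)ccc3c2=O)cc1` has not yet been measured. It differs from compound 2 by 4-ethoxyphenyl in place of 4-methoxybenzyl on an amide-type nitrogen. The change puts the aromatic ring directly on the amide nitrogen, as in compound 1, and exchanges methoxy for ethoxy. Since the measured step of a 1.8-fold higher number from compound 1 to compound 2 (0.24 log units; within the scatter) was within the scatter, the expected step of a 1.6-fold lower number from compound 2 to compound 3 (0.21 log units; within the scatter) is likewise no larger than the scatter. Compound 3 is therefore estimated at 14000 nM in this assay, with a range from 5000 nM to 40000 nM.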

Compound 3, half-maximal inhibitory concentration: > 100000 nM
Compound 3 gave a limit, no number (the forecaster's own chance of this, stated with the estimate: 10%); middle value at least 7.1-fold (0.85 log units) from the limit.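

In this assay compound 3 reads as a limit of the assay and not as a number: the limit of > 100000 nM in this assay, at which 1 of the 3 values shown sits. The earlier pair gave no sign that the group on the amide-type nitrogen mattered, yet 4-ethoxyphenyl in place of 4-methoxybenzyl gives an at least 4.4-fold higher number from compound 2 to compound 3 (0.64 log units; beyond the scatter), and the same group in place of 3-methoxyphenyl gives an at least 7.8-fold higher number from compound 1 to compound 3 (0.89 log units; beyond the scatter). The same atoms joined differently can therefore separate a measurable inhibitor from one that reaches the limit, and compound 1 shows that an aromatic ring directly on that nitrogen does not by itself go with the loss.

On these data alone, whether the loss follows the ethoxy group itself or its place on the ring remains open. Also open, as far as these compounds go, is how a longer chain such as propoxy, or an amine in place of the ethoxy group, would read.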